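Ethoxy to methoxy: expected effect on transferase inhibition

A few compounds are considered here, and "the series" means these few. Any claim that something is new, unique, unknown or untested is made for them only; others in the source may bear on it.

For the measured compounds named here, compound 3 `CCOc1ccc(/C=C2\CN(CC(=O)O)c3ccc(C)cc3C2=O)cc1` gives 25.8% in an assay on HL-60 cells for inhibition of glutathione S-transferase P (Homo sapiens), read by spectrophotometry, tested at 20 uM (on this read-out higher numbers stand for more inhibition at the one concentration tested (going by the name of the read-out) and lower numbers for less inhibition), the highest of the three numbers so far, though its steps to compound 2 `Cc1ccc2c(c1)C(=O)/C(=C/c1ccc(Cl)cc1)CN2CC(=O)O` at 20.7% and to compound 1 `Cc1ccc2c(c1)C(=O)/C(=C/c1ccc(F)cc1)CN2CC(=O)O` at 16.1% both lie within the scatter. Compound 4 `COc1ccc(/C=C2\CN(CC(=O)O)c3ccc(C)cc3C2=O)cc1` differs from compound 3 by hydrogen in place of methyl on a saturated chain carbon bound to an oxygen on an aromatic ring. Going by the values given here, no measured step shortens the alkoxy chain itself; the steps that touch this region are replacements on the aromatic carbon, a number 9.7 percentage points higher from compound 1 to compound 3 (within the scatter) and a number 5.1 percentage points higher from compound 2 to compound 3 (within the scatter), together with a number 4.6 percentage points higher from compound 1 to compound 2 (within the scatter), all within the scatter. The change from ethoxy to methoxy is therefore expected to give no step beyond the scatter in this assay, a number 2.8 percentage points lower from compound 3 to compound 4 (within the scatter). Compound 4 is estimated at 23%, with a range of 10% to 36%.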

Compound 4, a percentage reported as inhibition, at one concentration (the size of the read-out at that concentration, not a potency): 17.5%
The estimate for compound 4 lay 5.5 percentage points above the measured number, and the stated range covers the measured number.
By their numbers in this assay, from the lowest: compounds 1, 4, 2 and 3 (each within the scatter of the next).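

The ethoxy to methoxy change on this aromatic carbon now has a direct reading in this assay, with hydrogen in place of methyl on the saturated chain carbon giving no step beyond the scatter (a number 8.3 percentage points lower from compound 3 to compound 4 (within the scatter)). Methoxy in place of chloro (a number 3.2 percentage points lower from compound 2 to compound 4 (within the scatter)) and methoxy in place of fluoro (a number 1.4 percentage points higher from compound 1 to compound 4 (within the scatter)) also stay within the scatter, so methoxy does not separate from the other groups at this position. Nothing available here bears on the cause of these numbers.

As far as these compounds go, whether a longer chain such as butoxy, or an amine, on this aromatic carbon would give a step beyond the scatter remains open.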